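Swapping the ester side group of compound 3

The source may report more compounds than this note shows. Statements on the series, on what has been measured and on what is new or still open speak of the compounds shown alone.

In a physicochemical assay for lipophilicity, read by HPLC, measured as chromatographic lipophilicity (a higher number here means a more lipophilic compound, a lower number a more polar compound), compound 3 `CCC/N=C1\S/C(=C\c2ccc(C(=O)OCc3oc(=O)oc3C)cc2)C(=O)N1c1ccccc1O` stands highest at 3.3, ahead of compound 2 `CCC/N=C1\S/C(=C\c2ccc(C(=O)OCC3COC(=O)O3)cc2)C(=O)N1c1ccccc1O` at 2.8 and compound 1 `CCC/N=C1\S/C(=C\c2ccc(C(=O)OCCCO)cc2)C(=O)N1c1ccccc1O` at 2.3. Compound 4 `CCC/N=C1\S/C(=C\c2ccc(CCC(=O)OC)cc2)C(=O)N1c1ccccc1O` differs from compound 3 as follows: a group of 6 heavy atoms (4 carbon, 2 oxygen; no ring) in place of a group of 11 heavy atoms (6 carbon, 5 oxygen; one five-membered aromatic ring with 2 hetero atoms), on an aromatic carbon, with 2-(methoxycarbonyl)ethyl entering on an aromatic carbon. The closest evidence is a number 0.50 log units higher from compound 1 to compound 2 (beyond the scatter), a number 0.50 log units higher from compound 2 to compound 3 (beyond the scatter) and a number 1.00 log units higher from compound 1 to compound 3 (beyond the scatter). All three are modest, and all were made on a saturated chain carbon, so they bear on this change only indirectly and fix no direction for it. The expected change is therefore small, a number 0.10 log units lower from compound 3 to compound 4 (within the scatter), with no shift beyond the scatter expected. Compound 4 is estimated at 3.2, with an expected range from 2.7 to 3.7.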

Compound 4, distribution coefficient: 3.5
For compound 4 the middle estimate is 0.30 log units below the measured one; measured number inside the range.
By their numbers in this assay, from the lowest: compound 1; then compound 2; then compounds 3 and 4 (each within the scatter of the next).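

On the aromatic carbon para to a large group, 2-(methoxycarbonyl)ethyl, a group of 6 heavy atoms with no ring, replaces a group of 11 heavy atoms with a five-membered aromatic ring, giving a number 0.20 log units higher from compound 3 to compound 4 (within the scatter) in this assay. The same change of group gives a number 0.70 log units higher from compound 2 to compound 4 (beyond the scatter) and a number 1.20 log units higher from compound 1 to compound 4 (beyond the scatter). Nothing measured here accounts for these steps.

From the compounds shown here alone, it remains open how a carboxylic acid or an amine on this aromatic carbon would read in this assay. Going by these compounds, a longer chain ending in the same methyl ester is equally open.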